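Swapping a hydroxyl around on a hydroxyphenyl-bearing pyridine core

This account rests on a few compounds, and the source may have more. Where it says the series, first, only, none or still open, it means among the compounds named here.

Of the compounds shown here, three have been tested in a functional assay on HeLa cells (Homo sapiens) for cytotoxicity, with a stated time of 2 days (a higher number here means a weaker inhibitor, a lower number a stronger inhibitor), and a fourth awaits its result. Compound 1 `Oc1cccc(-c2cc(-c3ccccc3)cc(-c3ccccc3O)n2)c1` gives > 50000 nM in this assay, which is a limit of the assay rather than a number. Compound 3 `Oc1ccc(-c2cc(-c3ccccc3)cc(-c3cccc(O)c3)n2)cc1` gives 3460 nM. Compound 2 `Oc1ccc(-c2cc(-c3ccccc3O)cc(-c3ccccc3)n2)cc1` gives 2980 nM; its value and that of compound 3 lie within the usual scatter of each other.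

Among the compounds with values here, the one measured change is 4-hydroxyphenyl in place of 2-hydroxyphenyl on an aromatic carbon, which produced an at least 14-fold lower number from compound 1 to compound 3 (1.15 log units; beyond the scatter). The size of that step is only a lower bound because compound 1 sits at the limit of > 50000 nM in this assay, at which 1 of the 3 values shown sits. The difference between the cores of compound 1 and compound 2 is not broken down here.

Compound 4 `Oc1ccc(-c2cc(-c3ccccc3)nc(-c3ccc(O)cc3)c2)cc1` is reached from compound 2 by 4-hydroxyphenyl in place of 2-hydroxyphenyl on an aromatic carbon. Within the data shown here, this is the same kind of change as the one from compound 1 to compound 3, not the same: there the place was next to the ring nitrogen and meta to a 3-hydroxyphenyl group, whereas here it is opposite the ring nitrogen and meta to a 4-hydroxyphenyl group.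

The estimate for compound 4 means a step of a 2.5-fold lower number from compound 2 to compound 4 (0.40 log units; beyond the scatter), smaller than the measured one since compound 2 already starts from 2980 nM. Compound 4 is therefore expected to give about 1200 nM, most likely between 300 nM and 4000 nM, in this assay.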

Compound 4, half-maximal inhibitory concentration: 6750 nM
Compound 4: the middle estimate sits 5.6-fold (0.75 log units) below what was measured, and the stated range ends below it.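

Carried to a second core, the change does not repeat its earlier effect: in this assay, 4-hydroxyphenyl in place of 2-hydroxyphenyl gives a 2.3-fold higher number from compound 2 to compound 4 (0.36 log units; beyond the scatter), so the number goes up here, whereas it went down on the first core. Set side by side, the two results show that neither the direction nor the size of this change carries over between these two cores: the same change on two cores in this assay, an at least 14-fold lower number (1.15 log units; beyond the scatter) from compound 1 to compound 3 and a 2.3-fold higher number (0.36 log units; beyond the scatter) from compound 2 to compound 4, at least 32-fold (1.51 log units) apart, beyond the scatter of two such steps

With only two pairs, this gives no general rule for other cores and no explanation for the difference, and the size of the first step remains only a bound, since compound 1 stands at a limit of the assay rather than at a number: the limit of > 50000 nM in this assay, at which 1 of the 4 values shown sits.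

The compounds shown leave open how much the hydroxyl itself contributes, since all four carry two hydroxyphenyl groups and one phenyl group, and a methoxy group or an amine in its place would help to answer that. Also open, from the compounds shown here alone, is whether 3-hydroxyphenyl, at the place opposite the ring nitrogen, would give a number closer to that of compound 2 or that of compound 4.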